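Cyclopropyl in place of methoxy: a stability estimate

A few compounds are considered here, and "the series" means these few. Any claim that something is new, unique, unknown or untested is made for them only; others in the source may bear on it.

Compound 1 `COCCn1c(-c2ccccc2Cl)nc2c(N3CCN(C(C)=O)CC3)nc(C)nc21` gives 34%
Compound 2 `CC(=O)NCCn1c(-c2ccccc2Cl)nc2c(N3CCN(C)CC3)nc(C)nc21` gives 40%
Compound 3 `COc1ccccc1-c1nc2c(N3CCN(C)CC3)nc(C)nc2n1C1CCOCC1` gives 36%

These numbers come from an ADME assay (liver) for metabolic stability, with Liver microsome (Canis lupus familiaris) as the target, read by LC-MS, using microsomes, with a stated time of 30 min, tested at 4 uM; a lower number here means that less of the compound is left, a higher number that more of the compound is left. Compound 3 (36%) stands within the usual scatter of both compound 1 and compound 2, so the three cannot be told apart here.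

Compound 4 `Cc1nc(N2CCN(C)CC2)c2nc(-c3ccccc3C3CC3)n(C3CCOCC3)c2n1` differs from compound 3 at one place: cyclopropyl in place of methoxy on an aromatic carbon. This is 2-methoxyphenyl to 2-cyclopropylphenyl, with cyclopropyl in place of methoxy on an aromatic carbon.

Within the data shown here, no measured pair differs at a single place, so nothing here shows the effect of this change directly. The three compounds differ in several places, yet their values stay within the scatter, so no step beyond the scatter is expected in this assay. The expected change is a number 4 percentage points lower from compound 3 to compound 4 (within the scatter), which is a small estimated step. Compound 4 is estimated at 32% (expected range 14% to 52%).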

Compound 4, percent of the compound remaining: 69%
Estimate against measurement, compound 4: 37 percentage points below; measured number above the stated range.
By their numbers in this assay, from the lowest: compounds 1, 3 and 2 (each within the scatter of the next); then compound 4.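

In this assay, among these compounds, the change from 2-methoxyphenyl to 2-cyclopropylphenyl gives a number 33 percentage points higher from compound 3 to compound 4 (beyond the scatter) and forms the first measured pair that differs in one place. It shows that a single group at this position can move the read-out beyond the usual scatter, which the first three compounds, differing in several places at once, did not reveal. Nothing available here accounts for the size of this step.

Going by these compounds, it remains open whether other groups at this position, such as ethyl or tert-butyl, would give a similar result. It also remains open whether the same change would have a similar effect on the other compounds shown.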